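A few compounds are considered here, and "the series" means these few. Any claim that something is new, unique, unknown or untested is made for them only; others in the source may bear on it.

Measured in a functional assay on HeLa cells (Homo sapiens) for inhibition, with a stated time of 72 h (a higher number here means that more compound is needed for the effect, a lower number that less compound is needed), so far:
compound 1 `COc1cc(CNCc2ccncc2)ccc1OCc1ccc(Cl)c(Cl)c1` gives 4000 nM
compound 2 `COc1cc(CNCc2ccncc2)ccc1OCc1ccc(F)cc1` gives 6400 nM
compound 3 `COc1cc(CNCc2ccncc2)ccc1OCc1ccc(Cl)nc1` gives 400 nM

Compound 3 has the lowest number of the three, clear of both others. Compound 4 `COc1cc(CNCc2ccncc2)ccc1OCc1cnc(Cl)c(Cl)c1` carries 5,6-dichloropyridin-3-yl in place of 6-chloropyridin-3-yl, with chloro in place of hydrogen on an aromatic carbon as the change, chloro in place of hydrogen on an aromatic carbon. Among the measured compounds shown here, no measured step adds a chloro to this ring. The larger moves, a 10-fold lower number from compound 1 to compound 3 (1.00 log units; beyond the scatter) and a 16-fold lower number from compound 2 to compound 3 (1.20 log units; beyond the scatter), both arrive at 6-chloropyridin-3-yl. For the measured compounds named here, with a 1.6-fold higher number from compound 1 to compound 2 (0.20 log units; within the scatter) as the only step between two halogen-bearing phenyl groups, no step beyond the scatter is expected in this assay, with a slight lean towards a higher number. The estimated step is a 1.8-fold higher number from compound 3 to compound 4 (0.24 log units; within the scatter) on this reasoning. Compound 4 is estimated at 700 nM, with an expected range from 200 nM to 2500 nM overall.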

Compound 4, half-maximal effective concentration: 220 nM
Beside the measured number, compound 4's estimate is 3.2-fold (0.50 log units) above it; the range from low to high includes it.
By their numbers in this assay, from the lowest: compounds 4 and 3 (each within the scatter of the next); then compounds 1 and 2 (each within the scatter of the next).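

In this assay, chloro in place of hydrogen at this position, ortho to a chloro group and two atoms from the ring nitrogen, gives a 1.8-fold lower number from compound 3 to compound 4 (0.26 log units; within the scatter), so the second chloro leaves the number within the scatter of compound 3. The low numbers persist with 5,6-dichloropyridin-3-yl, which carries its two chloro groups as 3,4-dichlorophenyl does but adds a ring nitrogen: an 18-fold lower number from compound 1 to compound 4 (1.26 log units; beyond the scatter), and a 29-fold lower number from compound 2 to compound 4 (1.46 log units; beyond the scatter). No measurement accounts for these steps. Going by these compounds, whether methyl, methoxy or an amine at this position would stay within the scatter of chloro remains open.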